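A few compounds are considered here, and "the series" means these few. Any claim that something is new, unique, unknown or untested is made for them only; others in the source may bear on it.

In an ADME assay (liver) for metabolic stability, with Liver microsome (Rattus norvegicus) as the target, using microsomes and NADPH, with a stated time of 30 min, tested at 1 uM (on this read-out higher numbers stand for fast clearance and lower numbers for slow clearance), compound 1 (`Nc1ccc(S(=O)(=O)N2CCN(c3ncc(C(O)(C(F)(F)F)C(F)(F)F)cc3Br)CC2)cn1`) gives 32 mL.min-1.g-1, compound 2 (`Nc1ccc(S(=O)(=O)N2CCN(c3ncc(C(O)(C(F)(F)F)C(F)(F)F)cc3C#CC3CC3)CC2)cn1`) gives 67 mL.min-1.g-1 and compound 3 (`Nc1ccc(S(=O)(=O)N2CCN(c3ncc(C(O)(C(F)(F)F)C(F)(F)F)cc3C#CCO)CC2)cn1`) gives 65 mL.min-1.g-1. Compound 3 therefore stands level with compound 2 and clear of compound 1. Compound 4 (`COCC#Cc1cc(C(O)(C(F)(F)F)C(F)(F)F)cnc1N1CCN(S(=O)(=O)c2ccc(N)nc2)CC1`) has 3-methoxyprop-1-yn-1-yl in place of 3-hydroxyprop-1-yn-1-yl: methyl in place of hydrogen on an oxygen on a saturated carbon. For the measured compounds named here, no measured step makes this exact change. The nearest evidence is the swap of cyclopropyl for hydroxymethyl on a triple-bonded carbon, a 1.0-fold lower number from compound 2 to compound 3 (0.01 log units; within the scatter). Both alkynes differ modestly from bromo: a 2.1-fold higher number from compound 1 to compound 2 (0.32 log units; beyond the scatter) and a 2.0-fold higher number from compound 1 to compound 3 (0.31 log units; beyond the scatter). No step beyond the scatter is therefore expected in this assay. The expected change is a 1.2-fold higher number from compound 3 to compound 4 (0.06 log units; within the scatter). For compound 4 the estimated value is 75 mL.min-1.g-1, with an expected range of 40 mL.min-1.g-1 to 140 mL.min-1.g-1.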

Compound 4, intrinsic clearance in microsomes: 399 mL.min-1.g-1
Compound 4: middle estimate off by 5.3-fold (0.73 log units), on the low side; the measured number lies above the stated range.
By their numbers in this assay, from the lowest: compound 1; then compounds 3 and 2 (each within the scatter of the next); then compound 4.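

Methyl in place of hydrogen on an oxygen on a saturated carbon, a single added carbon, gives a 6.1-fold higher number from compound 3 to compound 4 (0.79 log units; beyond the scatter) in this assay. Methoxymethyl in place of cyclopropyl gives a 6.0-fold higher number from compound 2 to compound 4 (0.77 log units; beyond the scatter), and 3-methoxyprop-1-yn-1-yl in place of bromo gives a 12-fold higher number from compound 1 to compound 4 (1.10 log units; beyond the scatter), so the level reading shared by the two earlier alkynes does not extend to every alkyne substituent here. Nothing available accounts for this jump.

Open, as far as these compounds go, is whether a longer ether such as ethoxy tracks the methoxy result, and where an amine such as dimethylamino in place of the hydroxy would fall.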